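A few compounds are considered here, and "the series" means these few. Any claim that something is new, unique, unknown or untested is made for them only; others in the source may bear on it.

Measured so far:
compound 1 `COc1cc(-c2nn(-c3cccc(NC(=O)c4cccc(C(F)(F)F)c4)c3)cc2-c2ccncc2)ccc1Cl` — > 50000 nM
compound 2 `COc1cc(-c2nn(-c3cccc(NC(=O)Nc4ccc(Cl)c(C(F)(F)F)c4)c3)cc2-c2ccncc2)ccc1Cl` — > 32500 nM
compound 3 `COc1cc(-c2nn(-c3cccc(NC(=O)c4ccccc4)c3)cc2-c2ccncc2)ccc1Cl` — > 100000 nM

In a functional assay on NCI-H522 cells (Homo sapiens) for inhibition, read by sulforhodamine B assay, with a stated time of 48 h (on this read-out higher numbers stand for lower toxicity in this test and lower numbers for higher toxicity in this test), none of the three gives a number. Compound 3 gives only a limit of the assay, (the limit of > 100000 nM in this assay, at which 1 of the 3 values shown sits). Compound 1 likewise sits at a limit, (the limit of > 50000 nM in this assay, at which 1 of the 3 values shown sits). Compound 2 sits at a limit, (the limit of > 32500 nM in this assay, at which 1 of the 3 values shown sits). Compound 3 therefore stands only at a limit, and the two other values are limits too, so no ordering among the three can be read.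

The step to compound 4 `COc1cc(-c2nn(-c3cccc(NC(=O)Nc4ccc(Cl)c(Cl)c4)c3)cc2-c2ccncc2)ccc1Cl` is (3,4-dichlorophenyl)amino in place of phenyl on a carbonyl carbon. The closest measured step is a step that the two limits leave unreadable from compound 2 to compound 3, and the further one a step that the two limits leave unreadable from compound 1 to compound 3; both are unreadable, so no direction or size can be taken from them. Compound 4 is expected to remain at or near a limit, an at least 2.0-fold lower number from compound 3 to compound 4 (0.30 log units; that floor lies within the scatter). Compound 4 is estimated at 50000 nM, within 20000 nM to 100000 nM.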

Compound 4, concentration lethal to 50% of the cells: > 50000 nM
Compound 4 gave a limit, no number; the forecaster's own chance of this, stated with the estimate: 80%; the middle value sits exactly at the limit.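

Compound 4 gives only a limit, as do compound 1, compound 2 and compound 3, so its steps to those three cannot be read. The compounds shown leave open whether any change on the carbonyl carbon alters toxicity in this test.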